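Isomeric Amines on a Shared Bicyclic Core

The source may hold more compounds than are shown below. What is called first, only, known or untested is meant among the compounds shown, and "the series" means these compounds.

Measured so far:
compound 1, `O=C(CCc1ccc(C(F)(F)F)cc1)Nc1ccc2nc(N3CC4CC3CN4)ccc2c1`, 490 nM
compound 2, `CN(c1ccc2cc(NC(=O)CCc3ccc(C(F)(F)F)cc3)ccc2n1)C1CCCC1`, 350 nM

Compound 2 stands with the lowest of the two numbers obtained in a functional assay on HEK293 cells for activation of melanin-concentrating hormone receptor 1 (Rattus norvegicus), read by inositol phosphate accumulation; on this read-out higher numbers stand for an effect only at larger amounts of compound and lower numbers for an effect already at smaller amounts; its nearest neighbour is compound 1, and the step of a 1.4-fold lower number from compound 1 to compound 2 (0.15 log units; within the scatter) lies within the scatter, so no order between them can be read from these two values. Compound 3 `O=C(CCc1ccc(C(F)(F)F)cc1)Nc1ccc2nc(N3CCCCCC3)ccc2c1` has not yet been measured. It differs from compound 2 in one place: azepan-1-yl in place of cyclopentyl(methyl)amino on an aromatic carbon. The two compounds carry the same atoms, joined differently.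

Within the data shown here, only one measured step bears on this change, the exchange of one seven-heavy-atom amine for another at the same aromatic carbon from compound 1 to compound 2, which gave a 1.4-fold lower number from compound 1 to compound 2 (0.15 log units; within the scatter). Since that exchange stayed within the scatter, a further exchange of like size at the same place is expected to do the same, in no particular direction. The step expected here is a 1.1-fold higher number from compound 2 to compound 3 (0.06 log units; within the scatter). Compound 3 is therefore estimated at 400 nM, with a range from 150 nM to 1100 nM.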

Compound 3, half-maximal effective concentration: 1800 nM
The estimate for compound 3 lay 4.5-fold (0.65 log units) below the measured number; the whole stated range lies below it.
By their numbers in this assay, from the lowest: compounds 2 and 1 (each within the scatter of the next); then compound 3.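

In this assay, the change to azepan-1-yl from cyclopentyl(methyl)amino, with the same atoms joined differently, gave a 5.1-fold higher number from compound 2 to compound 3 (0.71 log units; beyond the scatter), which shows that this position, on an aromatic carbon next to the ring nitrogen, responds to how a group is built and not only to its atom count. Replacing the group of compound 1, with its two five-membered non-aromatic rings, gave a 3.7-fold higher number from compound 1 to compound 3 (0.57 log units; beyond the scatter), so azepan-1-yl stands apart from both earlier amines, although the numbers of compound 1 and compound 2 lie within the scatter of each other. Nothing available gives a reason for this separation.

The compounds shown leave open whether the number follows the size of the ring that contains the nitrogen, a question that piperidin-1-yl or pyrrolidin-1-yl at the same carbon would address. They also leave open whether an open-chain amine such as dipropylamino would fall with compound 1 and compound 2 or with compound 3.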